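Acyl carbamate series: undecyl ester in place of phenylpropyl

A few compounds are considered here, and "the series" means these few. Any claim that something is new, unique, unknown or untested is made for them only; others in the source may bear on it.

Measured so far:
compound 1 `CCCCCCCCC(C)OC(=O)NC(=O)Nc1c(C(C)C)cccc1C(C)C`, 750 nM
compound 2 `O=C(NC(=O)Oc1c(-c2ccccc2)cccc1-c1ccccc1)Oc1c(-c2ccccc2)cccc1-c1ccccc1`, 230 nM
compound 3 `CC(C)c1cccc(C(C)C)c1OC(=O)NC(=O)OCCCc1ccccc1`, 660 nM

All three compounds were run in an assay on microsomes from intestine for inhibition of acyl-CoA:cholesterol acyltransferase (Oryctolagus cuniculus); a higher number here means a weaker inhibitor, a lower number a stronger inhibitor. Compound 3 gives 660 nM, the second highest of the three numbers. Its nearest neighbour is compound 1, which gives 750 nM; the gap between the two lies within the usual scatter, so no order can be read between them. Compound 2 gives 230 nM, the lowest of the three numbers, and its gap to compound 3 lies beyond the scatter.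

Compound 4 `CCCCCCCCCCCOC(=O)NC(=O)Oc1c(C(C)C)cccc1C(C)C` has not yet been measured in this assay. Compared with compound 3 the change is: octyl in place of phenyl on a saturated chain carbon, three bonds along the chain from an oxygen next to a carbonyl group. Within the data shown here, no step between measured compounds isolates this change, so there is no direct precedent for it. The expectation is that the number stays close to that of compound 3, since compound 1, which also carries a long saturated chain, gives 750 nM in this assay. The step of a 1.2-fold lower number from compound 3 to compound 4 (0.08 log units; within the scatter) is therefore expected to be small and not beyond the scatter in either direction. For compound 4 the estimate in this assay is 550 nM, with a range from 200 nM to 1500 nM.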

Compound 4, half-maximal inhibitory concentration: 140 nM
Compound 4: the middle estimate sits 3.9-fold (0.59 log units) above what was measured; measured number below the stated range.
By their numbers in this assay, from the lowest: compounds 4 and 2 (each within the scatter of the next); then compounds 3 and 1 (each within the scatter of the next).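

In this assay, among these compounds, octyl in place of phenyl on a saturated chain carbon, three bonds along the chain from an oxygen next to a carbonyl group, gives a 4.7-fold lower number from compound 3 to compound 4 (0.67 log units; beyond the scatter), the only step that isolates a change at this position. The position is therefore sensitive to the group it carries, and a six-membered aromatic ring of carbon only is not required there, as compound 4, with no ring in this group, gives the lower number. The step swaps phenyl, with 6 heavy atoms, for octyl, with 8 heavy atoms, so loss of the ring and gain in size travel together in this single pair, and no measurement on hand explains the step.

The compounds shown leave open whether the ring or the chain length carries the step, a question that cyclohexyl at this position, or a shorter chain such as butyl, would address. They also leave open whether a longer chain continues the trend or reverses it, and whether a carboxylic acid or an amine at the chain end is tolerated.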